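The compounds below may be only part of what the source reports. "The series", "measured", "known", "first", "only" and "open" are said of these compounds alone.

Compound 1 `C/C=C(\C)C(=O)O[C@@H]1[C@]2(OC(=O)CCCC)C=C3C4=CC(=O)O[C@@H](c5ccoc5)[C@]4(C)CC[C@@H]3[C@@]3(C)[C@H](C[C@]1(C)[C@H]3[C@@H](OC(=O)CCCC)C(=O)OC)O2` and compound 2 `C/C=C(\C)C(=O)O[C@@H]1[C@]2(OC(=O)CCCC)C=C3C4=CC(=O)O[C@@H](c5ccoc5)[C@]4(C)CC[C@@H]3[C@@]3(C)[C@H](C[C@]1(C)[C@H]3[C@@H](O)C(=O)OC)O2` were tested in a functional assay on SK-OV-3 cells (Homo sapiens) for inhibition, read by MTT assay, with a stated time of 24 h; a higher number here means a weaker inhibitor, a lower number a stronger inhibitor. Compound 1 gives > 100000 nM, which is a limit of the assay and not a number. Among the compounds with values here, compound 2 gives 13700 nM, the only true number so far. Compound 3 `C/C=C(\C)C(=O)O[C@@H]1[C@]2(OC(=O)C3CC3)C=C3C4=CC(=O)O[C@@H](c5ccoc5)[C@]4(C)CC[C@@H]3[C@@]3(C)[C@H](C[C@]1(C)[C@H]3[C@@H](O)C(=O)OC)O2` follows from compound 2 by one change: cyclopropyl in place of butyl on a carbonyl carbon. Within the data shown here, only one measured step bears on this, and only indirectly: an at least 7.2-fold lower number from compound 1 to compound 2 (0.86 log units; beyond the scatter), with hydrogen in place of butylcarbonyl on an oxygen on a saturated carbon. On these data alone, it starts from a limit, (the limit of > 100000 nM in this assay, at which 1 of the 2 values shown sits), so its true size is unknown. That step removed a whole butylcarbonyl, whereas here the carbonyl stays and only butyl gives way to cyclopropyl. In this assay, no change beyond the scatter is therefore expected, and the estimated step is a 1.1-fold lower number from compound 2 to compound 3 (0.02 log units; within the scatter). The expected value for compound 3 is 13000 nM, with an estimated range from 4000 nM to 45000 nM.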

Compound 3, half-maximal inhibitory concentration: > 100000 nM
Compound 3 was reported as a limit; the forecaster's own chance of this, stated with the estimate: 15%; middle value at least 7.6-fold (0.88 log units) away from the limit.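

In this assay, the earlier step showed only what losing a whole butylcarbonyl does, whereas here the carbonyl stays and the group on this carbonyl carbon alone is exchanged, giving an at least 7.2-fold higher number from compound 2 to compound 3 (0.86 log units; beyond the scatter). So the read-out depends on what the carbonyl carries, and cyclopropyl does not stand in for butyl in compound 2. On these data alone, compound 3 gives > 100000 nM, which is a limit of the assay and not a number, and the true size of the step stays unknown because it ends at that limit: the limit of > 100000 nM in this assay, at which 2 of the 3 values shown sit.

As far as these compounds go, it remains open whether the loss goes with the ring or with the shorter carbon count, which an open propyl chain on this carbonyl carbon would help to separate. From the compounds shown here alone, how a longer chain or a phenyl ring here would read is also open.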